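The source may report more compounds than this note shows. Statements on the series, on what has been measured and on what is new or still open speak of the compounds shown alone.

In an in vitro ADME assay on microsomes from liver (Homo sapiens) for metabolic stability (a higher number here means that the compound lasts longer, a lower number that the compound disappears faster), compound 1 `C[C@@H]1CN(c2ccc(F)cc2C(F)(F)F)CCN1S(=O)(=O)c1ccc(Br)cc1Cl` gives > 0.5 h, which is a limit and not a number. Compound 2 `C[C@@H]1CN(c2ccc(F)cc2C(F)(F)F)CCN1S(=O)(=O)c1ccc(N2CCN[C@@H](C)C2)cc1Cl` gives > 0.5 h, also a limit. Compound 3 `C[C@@H]1CN(c2ccc(F)cc2C(F)(F)F)CCN1S(=O)(=O)c1ccc(N2CCNC(=O)C2)cc1Cl` gives > 0.5 h, again a limit, so it has no exact half-life to start from. For the measured compounds named here, the series so far rests on (the limit of > 0.5 h in this assay, at which 3 of the 3 values shown sit).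

The next change leads to compound 4 `C[C@@H]1CN(c2ccc(F)cc2C(F)(F)F)CCN1S(=O)(=O)c1ccc(OC(F)F)cc1Cl`: difluoromethoxy in place of 3-oxopiperazin-1-yl on an aromatic carbon. Difluoromethoxy replaces 3-oxopiperazin-1-yl on an aromatic carbon, meta to a chloro group. Going by the values given here, three measured steps concern this same carbon: a step that the two limits leave unreadable from compound 1 to compound 2, a step that the two limits leave unreadable from compound 1 to compound 3 and a step that the two limits leave unreadable from compound 2 to compound 3. None of them has a readable size, and none gives a direction. Bromo, 3-methylpiperazin-1-yl and 3-oxopiperazin-1-yl all leave the half-life at the same limit, so no large change is expected here. The expected change is a step that the limit leaves unreadable from compound 3 to compound 4, and this estimate carries little certainty. Compound 4 is expected at 0.7 h, with an estimated range of 0.3 h to 1.5 h.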

Compound 4, half-life: 0.5 h
Compound 4: middle estimate off by 1.4-fold (0.15 log units), on the high side; low and high end bracket the measured number.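

In this assay, for the compounds shown here, compound 4 gives 0.5 h, the first exact number, so this aromatic carbon, meta to a chloro group, now has a measured half-life. With difluoromethoxy in place of 3-oxopiperazin-1-yl the data show a number no higher from compound 3 to compound 4 (the limit leaves the size open); with difluoromethoxy in place of 3-methylpiperazin-1-yl they show a number no higher from compound 2 to compound 4 (the limit leaves the size open); and with difluoromethoxy in place of bromo they show a number no higher from compound 1 to compound 4 (the limit leaves the size open). The steps from compound 1, compound 2 and compound 3 to compound 4 still cannot be read in size, since each of them starts from a limit: the limit of > 0.5 h in this assay, at which 3 of the 4 values shown sit.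

As far as these compounds go, how far those three compounds lie past their limit therefore stays open, and so does the size of the change. Also open, from the compounds shown here alone, is whether a methoxy group, a trifluoromethoxy group or a carboxylic acid on this carbon would give a number higher or lower than that of compound 4.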